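The source may hold more compounds than are shown below. What is called first, only, known or untested is meant among the compounds shown, and "the series" means these compounds.

Compound 1, `Cc1ccc(-c2noc(CCCCCCC(=O)Nc3ccccc3N)n2)cc1`: in an assay on isolated protein for inhibition of histone deacetylase 8 (Homo sapiens), read by fluorescence, with a stated time of 10 min (a lower number here means a stronger inhibitor, a higher number a weaker inhibitor), compound 1 gives 8390 nM. Compound 2, `Nc1ccccc1NC(=O)CCCCCCc1nc(-c2ccc(C(F)(F)F)cc2)no1`: in this assay compound 2 gives > 10000 nM, which is a limit of the assay and not a number.

Compound 2 thus stands at the limit of > 10000 nM in this assay, at which 1 of the 2 values shown sits, and its true value is not known beyond that. Compound 3, `Nc1ccccc1NC(=O)CCCCCCc1nc(-c2ccc(Cl)cc2)no1`, is not yet measured; it differs from compound 2 in one place: chloro in place of trifluoromethyl on an aromatic carbon. Within the data shown here, only one measured step bears on this position, an at least 1.1-fold higher number from compound 1 to compound 2 (0.07 log units; that floor lies within the scatter), and its floor lies within the scatter, so the two values show no change beyond the scatter between methyl and trifluoromethyl there. With chloro entering at the same place, no step beyond the scatter is expected in this assay either, and the estimate means an at least 1.1-fold lower number from compound 2 to compound 3 (0.04 log units; that floor lies within the scatter). Compound 3 is therefore expected to give about 9000 nM, within 3000 nM to 30000 nM, with a fair chance that the assay again reports only a limit.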

Compound 3, half-maximal inhibitory concentration: > 10000 nM
Compound 3: no number, only a limit; the forecaster's own chance of this, stated with the estimate: 45%; at least 1.1-fold (0.04 log units) between middle value and limit.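

Against methyl, chloro gives an at least 1.1-fold higher number from compound 1 to compound 3 (0.07 log units; that floor lies within the scatter), so a second group at this place now shows no change from methyl that can be told from the scatter. The values of compound 2 and compound 3 are both limits of the assay, so the step from trifluoromethyl to chloro cannot be read, and replacing the four heavy atoms of trifluoromethyl with the single chlorine does not yield a number in this assay. The limit has become the most common reading in this small set: the limit of > 10000 nM in this assay, at which 2 of the 3 values shown sit.

From the compounds shown here alone, how far compound 2 and compound 3 lie past that limit remains unknown, so it stays open whether either truly differs from compound 1. Also open, going by these compounds, is whether an amine or a carboxylic acid at this place would give a lower number than compound 1 at 8390 nM.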